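A few compounds are considered here, and "the series" means these few. Any claim that something is new, unique, unknown or untested is made for them only; others in the source may bear on it.

Measured compounds in this set:
compound 1 `Cc1ccccc1-n1cc(-c2ccc(NS(=O)(=O)c3c[nH]c(=O)[nH]c3=O)cc2)nn1` – 13600 nM
compound 2 `O=c1[nH]cc(S(=O)(=O)Nc2ccc(-c3cn(-c4ccccc4F)nn3)cc2)c(=O)[nH]1` – 7270 nM
compound 3 `O=c1[nH]cc(S(=O)(=O)Nc2ccc(-c3cn(-c4cccc(F)c4)nn3)cc2)c(=O)[nH]1` – > 20000 nM

In a functional assay on SGC-7901 cells (Homo sapiens) for antiproliferative activity, read by MTT assay, with a stated time of 24 h (a lower number here means a stronger inhibitor, a higher number a weaker inhibitor), compound 3 gives > 20000 nM, which is a limit of the assay and not a number. Compound 3 therefore sits at the limit of > 20000 nM in this assay, at which 1 of the 3 values shown sits, and has no numerical place among the three.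

Compound 4 `O=c1[nH]cc(S(=O)(=O)Nc2ccc(-c3cn(-c4ccccc4Cl)nn3)cc2)c(=O)[nH]1` differs from compound 3 by 2-chlorophenyl in place of 3-fluorophenyl on an aromatic nitrogen. Within the data shown here, two measured steps bear on this position, both running to the 3-fluorophenyl: an at least 2.7-fold higher number from compound 2 to compound 3 (0.43 log units; beyond the scatter) and an at least 1.4-fold higher number from compound 1 to compound 3 (0.16 log units; that floor lies within the scatter). Compound 4 runs the other way, back to a 2-substituted phenyl, so a return toward the range of compound 1 and compound 2 is expected in this assay. The expected step is an at least 2.2-fold lower number from compound 3 to compound 4 (0.34 log units; beyond the scatter). Compound 4 is estimated at 9000 nM, with a range from 3000 nM to 25000 nM.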

Compound 4, half-maximal inhibitory concentration: 2680 nM
Estimate against measurement, compound 4: 3.4-fold (0.53 log units) above; measured number below the stated range.
By their numbers in this assay, from the lowest: compound 4; then compounds 2 and 1 (each within the scatter of the next). At a limit, above all of these: compound 3.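

In this assay, among these compounds, the 2-chlorophenyl of compound 4 gives the first steps beyond the scatter among the 2-substituted phenyl groups: a 2.7-fold lower number from compound 2 to compound 4 (0.43 log units; beyond the scatter) and a 5.1-fold lower number from compound 1 to compound 4 (0.71 log units; beyond the scatter). Compound 3 remains at a limit of the assay, not a number: the limit of > 20000 nM in this assay, at which 1 of the 4 values shown sits. The step to 2-chlorophenyl, an at least 7.4-fold lower number from compound 3 to compound 4 (0.87 log units; beyond the scatter), is therefore only a floor.

On these data alone, whether a bromo, methoxy or amino group in place of the chloro would lower the number further remains open.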